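Halogen swap in the thioacrylic acid series

The source may report more compounds than this note shows. Statements on the series, on what has been measured and on what is new or still open speak of the compounds shown alone.

Measured so far in an assay on isolated protein for inhibition of Calpain-1 catalytic subunit (Sus scrofa); on this read-out lower numbers stand for stronger inhibition and higher numbers for weaker inhibition:
compound 1, `O=C(O)/C(S)=C/c1ccccc1Cl`, 20700 nM
compound 2, `O=C(O)/C(S)=C/c1ccc(Br)cc1`, 1500 nM
compound 3, `O=C(O)/C(S)=C/c1ccccc1Br`, 9100 nM

Compound 2 gives the lowest number of the three; compound 3 and compound 1 are beyond the scatter above it. The difference between the cores of compound 2 and compound 3 is not broken down here. Within the core of compound 3 the change to compound 1 is chloro in place of bromo on an aromatic carbon, and the step is a 2.3-fold higher number from compound 3 to compound 1 (0.36 log units; beyond the scatter).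

Compound 4, `O=C(O)/C(S)=C/c1ccc(Cl)cc1`, is not yet measured. From compound 2 it differs by chloro in place of bromo on an aromatic carbon. This is the same kind of change, though the place differs: ortho to a group of 6 heavy atoms in the first case, para to a group of 6 heavy atoms here. Compound 4 is expected to follow the step seen in this assay for compound 1, resting on a 2.3-fold higher number from compound 3 to compound 1 (0.36 log units; beyond the scatter), so a step of about a 2.3-fold higher number from compound 2 to compound 4 (0.36 log units; beyond the scatter) is estimated. Compound 4 is thus expected at about 3400 nM, within 1500 nM to 8000 nM.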

Compound 4, half-maximal inhibitory concentration: 15000 nM
Estimate against measurement, compound 4: 4.4-fold (0.64 log units) below; measured number above the stated range.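

In this assay the step for chloro in place of bromo on an aromatic carbon is a 10-fold higher number from compound 2 to compound 4 (1.00 log units; beyond the scatter) and the two cores agree in direction but not in size: the same change on two cores in this assay, a 2.3-fold higher number (0.36 log units; beyond the scatter) from compound 3 to compound 1 and a 10-fold higher number (1.00 log units; beyond the scatter) from compound 2 to compound 4, 4.4-fold (0.64 log units) apart, beyond the scatter of two such steps.
The direction of this change therefore carried from one core to the other in these two pairs, while the size of the step from one core did not give the size on the other.
Two pairs do not show why the sizes differ, nor do they establish a rule for the whole series.

The compounds shown carry only bromo or chloro on the aromatic ring, so the effect of a fluoro, methoxy or nitrile group there remains open. Also open, going by these compounds, is how an amide or a methyl ester in place of the carboxylic acid would read in this assay.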